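Substituent on the aromatic nitrogen: the cyclohexyl analogue

This account rests on a few compounds, and the source may have more. Where it says the series, first, only, none or still open, it means among the compounds named here.

Three compounds share one core and differ only in the group on an aromatic nitrogen. Compound 1 `CC(C)n1nc(C(=O)N[C@H]2COc3ccccc3N(C)C2=S)nc1Cc1ccccc1` gives 360 nM in a functional assay on HT-29 cells (Homo sapiens) for inhibition, read by luminescence and CellTiter-Glo, with a stated time of 24 h; a lower number here means that less compound is needed, a higher number that more compound is needed for the effect. Compound 2 `CC(C)Cn1nc(C(=O)N[C@H]2COc3ccccc3N(C)C2=S)nc1Cc1ccccc1` gives 1230 nM in this assay, and compound 3 `CN1C(=S)[C@@H](NC(=O)c2nc(Cc3ccccc3)n(CCC(F)(F)F)n2)COc2ccccc21` gives 1550 nM in this assay. Compound 3 stands highest of the three numbers: the step of a 1.3-fold higher number from compound 2 to compound 3 (0.10 log units; within the scatter) is within the scatter, whereas the step of a 4.3-fold higher number from compound 1 to compound 3 (0.63 log units; beyond the scatter) lies beyond it. The next compound, compound 4 `CN1C(=S)[C@@H](NC(=O)c2nc(Cc3ccccc3)n(C3CCCCC3)n2)COc2ccccc21`, carries cyclohexyl in place of 3,3,3-trifluoropropyl on an aromatic nitrogen. Going by the values given here, no measured step exchanges one group of six heavy atoms for another at this position; the steps that bear on it are the two departures from isopropyl, a 3.4-fold higher number from compound 1 to compound 2 (0.53 log units; beyond the scatter) and a 4.3-fold higher number from compound 1 to compound 3 (0.63 log units; beyond the scatter), both modest increases, while a 1.3-fold higher number from compound 2 to compound 3 (0.10 log units; within the scatter) stayed within the scatter. Nothing in the set shows a ring at this position. For compound 4 in this assay a number near compound 3 or somewhat lower is expected, and the estimate is 700 nM with a range of 250 nM to 2000 nM. The expected step is therefore a 2.2-fold lower number from compound 3 to compound 4 (0.35 log units; beyond the scatter), which may not exceed the scatter.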

Compound 4, half-maximal effective concentration: 4000 nM
The estimate for compound 4 lay 5.7-fold (0.76 log units) below the measured number, outside the stated range (above it).
By their numbers in this assay, from the lowest: compound 1; then compounds 2 and 3 (each within the scatter of the next); then compound 4.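

In this assay the first ring at this position gives the highest number of the series, and each step to compound 4 is beyond the scatter: (a 2.6-fold higher number from compound 3 to compound 4 (0.41 log units; beyond the scatter)), (a 3.3-fold higher number from compound 2 to compound 4 (0.51 log units; beyond the scatter)) and (an 11-fold higher number from compound 1 to compound 4 (1.05 log units; beyond the scatter)). The last of these is large, whereas the departures from isopropyl to the open chains were modest, and cyclohexyl and 3,3,3-trifluoropropyl both have 6 heavy atoms and still differ beyond the scatter, so the heavy-atom count alone does not set the number here. No supporting measurement is available to explain this result.

From the compounds shown here alone, whether the ring itself or the overall size of the group drives the increase remains open. Cyclopropyl, cyclobutyl or a piperidine ring at this position would help separate the two.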